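Alkyne substituent series: step from cyclohexyl to octyl

This account rests on a few compounds, and the source may have more. Where it says the series, first, only, none or still open, it means among the compounds named here.

The three measured compounds share one core and differ at the group on the triple-bonded carbon or at the sulfonyl aryl. Compound 1 `CC(=O)Nc1nc(-c2cccc(NS(=O)(=O)c3cccc(Br)c3)c2)cs1` is recorded in a functional assay on A-375 cells (Homo sapiens) for antiproliferative activity, read by trypan blue exclusion, with a stated time of 48 h, tested at 1 uM (on this read-out higher numbers stand for a weaker effect at the one concentration tested and lower numbers for a stronger effect), as "not active" (no number reported), without a number. Compound 2 `CC(=O)Nc1nc(-c2cccc(NS(=O)(=O)c3ccc(C#CCO)cc3)c2)cs1` gives 81.3% in this assay. Compound 3 `CC(=O)Nc1nc(-c2cccc(NS(=O)(=O)c3ccc(C#CC4CCCCC4)cc3)c2)cs1` gives 52.3% in this assay, the lowest of the two numbers; the change a number 29 percentage points lower from compound 2 to compound 3 (beyond the scatter) is modest but beyond the scatter.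

Compound 4 `CCCCCCCCC#Cc1ccc(S(=O)(=O)Nc2cccc(-c3csc(NC(C)=O)n3)c2)cc1` carries the difference (octyl in place of cyclohexyl on a triple-bonded carbon). For the measured compounds named here, the only measured step that bears on it is the one from compound 2 to compound 3, where a carbon group in place of hydroxymethyl lowered the number by a modest amount. Going by the values given here, no step with a chain in place of a ring has been measured, so the direction is uncertain; the step of a number 7.3 percentage points lower from compound 3 to compound 4 (within the scatter) is expected to be small, within or just beyond the scatter, and the estimate for compound 4 in this assay is 45%, with a range from 20% to 75%.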

Compound 4, a percentage reported as activity, at one concentration (the size of the read-out at that concentration, not a potency): 39.6%
The estimate for compound 4 lay 5.4 percentage points above the measured number, and the stated range covers the measured number.
By their numbers in this assay, from the lowest: compound 4; then compound 3; then compound 2.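

Octyl in place of cyclohexyl on a triple-bonded carbon gives a number 12.7 percentage points lower from compound 3 to compound 4 (beyond the scatter) in this assay and shows that a ring is not needed here for a lower number, since the open chain goes further than the ring. Against the hydroxymethyl end of compound 2, the change gives a number 41.7 percentage points lower from compound 2 to compound 4 (beyond the scatter) and this is the largest step among the three compounds with numbers, which run from compound 4 through compound 3 to compound 2. Nothing available here accounts for either step.

Open, going by these compounds, is whether a chain shorter or longer than octyl, or a branched one such as tert-butyl, would move the number further. Also open, on these data alone, is whether an amine or a carboxylic acid at the end of the octyl chain would keep the number this low.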